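A few compounds are considered here, and "the series" means these few. Any claim that something is new, unique, unknown or untested is made for them only; others in the source may bear on it.

Three compounds share one core, a flavone-like scaffold bearing two methoxy groups and a phenyl ring carrying an ether side chain. Compound 1 `COc1cc(OC)c2c(=O)cc(-c3ccc(OCCBr)cc3)oc2c1` carries a 2-bromoethoxy chain, compound 2 `COc1cc(OC)c2c(=O)cc(-c3ccc(OCCN4CCCC4=O)cc3)oc2c1` a 2-(2-oxopyrrolidin-1-yl)ethoxy chain, and compound 3 `COc1cc(OC)c2c(=O)cc(-c3ccc(OCC(O)CO)cc3)oc2c1` a 2,3-dihydroxypropoxy chain.

In a functional assay (Homo sapiens) for antiproliferative activity, read by resazurin assay, with a stated time of 48 h, tested at 5 uM (on this read-out lower numbers stand for a weaker effect and higher numbers for a stronger effect at the one concentration tested), compound 1 is reported as "not active" (no number reported), with no number given. In this assay, among the measured compounds shown here, compound 2 gives 7%, which is the only number available in this set; it stands beside one further entry that has no single number, so no comparison within the scatter can be drawn from it.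

The move from compound 2 to compound 3 is 1,2-dihydroxyethyl in place of (2-oxopyrrolidin-1-yl)methyl on a saturated chain carbon bound to an oxygen on an aromatic ring, placed on a saturated chain carbon bound to an oxygen on an aromatic ring. For the measured compounds named here, no measured pair in this set shows the effect of such a change. Going by the values given here, both compounds measured so far sit at the weak end, so the step from compound 2 to compound 3 is expected to stay within the usual scatter, in either direction, as a number 1 percentage points higher from compound 2 to compound 3 (within the scatter). Compound 3 is therefore estimated at 8%, within a range from 0% to 22%.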

Compound 3, a percentage reported as inhibition, at one concentration (the size of the read-out at that concentration, not a potency): "not active" (no number reported)
For compound 3 the study gives words and no number, so the estimate cannot be set against anything.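

In this assay, among the compounds shown here, compound 3 gives "not active" (no number reported) and so no step from compound 2 to compound 3 can be read. Nothing shown here offers an explanation for this result. The compounds shown leave open whether replacing the 2-(2-oxopyrrolidin-1-yl)ethoxy chain with the 2,3-dihydroxypropoxy chain changes the percentage inhibition at all.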